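Working notes: isopentyl in place of phenyl, compound 4

The compounds below may be only part of what the source reports. "The series", "measured", "known", "first", "only" and "open" are said of these compounds alone.

Values in an ADME assay on Caco-2 cells (Homo sapiens) for permeability, read by LC-MS, in the apical to basolateral direction, with a stated time of 60 min, at pH 6.5; on this read-out lower numbers stand for lower permeability and higher numbers for higher permeability:
- compound 1 `O=C(NCc1cc(Cl)ccc1-n1cnnn1)[C@@H]1CC=NN1C(=O)[C@H](O)c1ccccc1`: 7 10^-6 cm/s
- compound 2 `CC(C)(C)[C@@H](O)C(=O)N1C[C@@H]2C[C@@H]2[C@H]1C(=O)NCc1cc(Cl)ccc1-n1cnnn1`: 17 10^-6 cm/s
- compound 3 `CC(C)(C)C[C@@H](O)C(=O)N1C[C@@H]2C[C@@H]2[C@H]1C(=O)NCc1cc(Cl)ccc1-n1cnnn1`: 25 10^-6 cm/s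

Compound 1 is the lowest of the three, and its gaps to compound 2 and compound 3 both lie beyond the usual scatter. Compound 4 `CC(C)CC[C@@H](O)C(=O)N1N=CC[C@H]1C(=O)NCc1cc(Cl)ccc1-n1cnnn1` keeps the core of compound 1 and differs at one place, on a saturated chain carbon bound to a carbonyl carbon and an oxygen on a saturated carbon: isopentyl in place of phenyl on a saturated chain carbon bound to a carbonyl carbon and an oxygen on a saturated carbon.

Among the measured compounds shown here, no measured step replaces phenyl with a chain. For the measured compounds named here, the only measured step, a 1.5-fold higher number from compound 2 to compound 3 (0.17 log units; within the scatter), exchanges tert-butyl for neopentyl at that same place and stays within the scatter. Compound 2 and compound 3 both carry such groups there, but on a different core from compound 1, so their values are only a loose guide. The expected change in this assay is a modest rise, a 2.1-fold higher number from compound 1 to compound 4 (0.33 log units; beyond the scatter), although a step within the scatter remains possible. Compound 4 is estimated at 15 10^-6 cm/s, with an expected range of 7 10^-6 cm/s to 30 10^-6 cm/s.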

Compound 4, apparent permeability: 29 10^-6 cm/s
The estimate for compound 4 lay 1.9-fold (0.29 log units) below the measured number, within the range that was stated.
By their numbers in this assay, from the lowest: compound 1; then compounds 2, 3 and 4 (each within the scatter of the next).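

On the core of compound 1, isopentyl in place of phenyl gives in this assay a 4.1-fold higher number from compound 1 to compound 4 (0.62 log units; beyond the scatter) and so lies beyond the usual scatter. Among the compounds shown here, this is the first exchange of a six-membered aromatic ring of carbon only for an open chain, on a saturated chain carbon bound to a carbonyl carbon and an oxygen on a saturated carbon. The earlier change at this place, a 1.5-fold higher number from compound 2 to compound 3 (0.17 log units; within the scatter), stayed within the scatter, so this position is now seen to move the read-out for at least one exchange, and nothing available bears on the origin of that step.

On these data alone, whether the same exchange carries the same size of step on the core of compound 2 remains open. Also open, as far as these compounds go, is how a cyclohexyl group, a longer chain or a chain ending in an amine would read at this place on the core of compound 1.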